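Exchanging a Cyclobutyl for Ethynyl on the Ammonium Chain

A few compounds are considered here, and "the series" means these few. Any claim that something is new, unique, unknown or untested is made for them only; others in the source may bear on it.

Among the measured compounds shown here, compound 1 `C[N+](C)(CCCC(=O)[O-])CC1CC1` is the first of the pair already measured. In an assay for inhibition of gamma-butyrobetaine dioxygenase (Homo sapiens), read by HPLC, with stated times of 15 min and 30 min (on this read-out higher numbers stand for weaker inhibition and lower numbers for stronger inhibition), compound 1 gives > 1000000 nM, which is a limit of the assay rather than a number. Compound 2 `C[N+](C)(CCCC(=O)[O-])CC1CCC1` carries a cyclobutyl in place of the cyclopropyl on a saturated chain carbon bound to an amine nitrogen. In this assay compound 2 gives > 1000000 nM, again a limit of the assay and not a number. The step that the two limits leave unreadable from compound 1 to compound 2 therefore cannot be read in size or direction. Where compound 2 stands is set by the limit of > 1000000 nM in this assay, at which 2 of the 2 values shown sit, so nothing separates it from compound 1 on the numbers shown.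

Compound 3 `C#CC[N+](C)(C)CCCC(=O)[O-]` differs from compound 2 by ethynyl in place of cyclobutyl on a saturated chain carbon bound to an amine nitrogen. For the measured compounds named here, the only measured step, a step that the two limits leave unreadable from compound 1 to compound 2, touches the same place but, sitting between two limits, offers no size to carry over. With both measured compounds at the limit, compound 3 is expected to give roughly 1000000 nM in this assay, within 300000 nM to 5000000 nM, and the step of a number no higher from compound 2 to compound 3 (the limit leaves the size open) is estimated to be none beyond the scatter.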

Compound 3, half-maximal inhibitory concentration: 1400 nM
The estimate for compound 3 lay 710-fold (2.85 log units) above the measured number, and the stated range ends above it.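

In this assay, the place on a saturated chain carbon bound to an amine nitrogen turns out to govern inhibition strongly: ethynyl in place of cyclobutyl gives an at least 710-fold lower number from compound 2 to compound 3 (2.85 log units; beyond the scatter), and ethynyl in place of cyclopropyl gives an at least 710-fold lower number from compound 1 to compound 3 (2.85 log units; beyond the scatter). The step between the two ring-bearing compounds cannot be read, so the earlier pair said nothing about this place, whereas compound 3 now gives the series its first number and sets ethynyl, with its triple bond and no ring, apart from both cyclopropyl and cyclobutyl. The true size of both new steps stays open because each one starts from a limit of the assay rather than a number: the limit of > 1000000 nM in this assay, at which 2 of the 3 values shown sit.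

What the compounds shown leave open is whether the triple bond itself matters or the loss of the ring and its heavy atoms, since ethynyl differs from cyclobutyl and cyclopropyl in all of these at once. A vinyl or an ethyl group at the same place would separate these readings, and a longer alkyne such as propynyl would show how much room the place allows.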